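The compounds below may be only part of what the source reports. "The series", "measured", "known", "first", "only" and "open" are said of these compounds alone.

Measured so far:
- compound 1, `Cc1nc(S(C)(=O)=O)ccc1Oc1ncnc(OC2CCN(C(=O)OC(C)(C)C#N)CC2)c1F`: 97%
- compound 2, `Cc1nc(S(C)(=O)=O)ccc1Oc1ncnc(OC2CCN(C(=O)OC3COC3)CC2)c1F`: 66%

In a functional assay on isolated protein for inhibition of Glucose-dependent insulinotropic receptor (Rattus norvegicus), read by HTRF and cAMP accumulation (on this read-out lower numbers stand for smaller maximal responses and higher numbers for larger maximal responses), compound 1 gives 97%, and compound 2 gives 66%. Among the measured compounds shown here, compound 2 thus holds the lower of the two numbers, and the only measured step, a number 31 percentage points lower from compound 1 to compound 2 (beyond the scatter), separates it from compound 1 by more than the usual scatter.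

Compound 3, `Cc1nc(S(C)(=O)=O)ccc1Oc1ncnc(OC2CCN(C(=O)OC3(C(F)(F)F)COC3)CC2)c1F`, differs from compound 2 by trifluoromethyl in place of hydrogen on a saturated ring carbon. For the measured compounds named here, no measured step covers this exact change; the step from compound 1 to compound 2 swapped the whole group on the oxygen and so bears on it only loosely. With compound 1 higher than compound 2 and compound 3 again carrying a more heavily substituted carbon on that oxygen, a moderate rise in this assay is expected, though wide uncertainty remains. The estimated step for compound 3 is a number 14 percentage points higher from compound 2 to compound 3 (beyond the scatter). Compound 3 is expected to give 80%, between 55% and 100%.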

Compound 3, largest response reached (reported as efficacy), in percent of the reference or control that the assay uses: 84%
Compound 3: the middle estimate sits 4 percentage points below what was measured; the range from low to high includes it.
By their numbers in this assay, from the lowest: compound 2; then compound 3; then compound 1.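

Trifluoromethyl on the saturated ring carbon, two ring bonds from the ring oxygen, is the first change shown that keeps the four-membered ring in place, and in this assay it gives a number 18 percentage points higher from compound 2 to compound 3 (beyond the scatter), so this carbon can tolerate substitution and the response depends on what it carries. The rise is only partial, with a number 13 percentage points lower from compound 1 to compound 3 (beyond the scatter), leaving the 1-cyano-1-methylethyl group of compound 1 with the largest response of the three. Nothing available here explains either step.

The compounds shown cannot tell whether trifluoromethyl is needed or whether a methyl group or a single fluorine on the same ring carbon would do the same. They also leave open how a cyclobutyl ring carrying trifluoromethyl, with no ring oxygen, would compare.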